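The source may hold more compounds than are shown below. What is called first, only, known or untested is meant among the compounds shown, and "the series" means these compounds.

Working notes on the series. Compound 1 `COc1ccc(-c2cc(/C=C/C(=O)c3ccc(N)cc3)[nH]n2)cc1` and compound 3 `COc1ccc(-c2cc(/C=C/C(=O)c3ccc(N)cc3)[nH]n2)cc1OC` share one core; compound 2 `COc1ccc(C(=O)/C=C/c2cc(-c3cc(OC)c(OC)c(OC)c3)n[nH]2)cc1OC` is built on another, and the difference between the two cores is not broken down here. In a functional assay on SK-MEL-5 cells (Homo sapiens) for cytotoxicity, read by sulforhodamine B assay, with a stated time of 48 h, tested at 1 uM (on this read-out lower numbers stand for a stronger effect and higher numbers for a weaker effect at the one concentration tested), compound 1 gives 90%, compound 3 gives 94% and compound 2 gives 91%. The change methoxy in place of hydrogen on an aromatic carbon made a number 4 percentage points higher from compound 1 to compound 3 (within the scatter). Compound 4 `COc1cc(C(=O)/C=C/c2cc(-c3cc(OC)c(OC)c(OC)c3)n[nH]2)cc(OC)c1OC` carries the same kind of change from compound 2, (methoxy in place of hydrogen on an aromatic carbon); around the place the added detail is that the entering group is also meta to a methoxy group. The expectation for compound 4 rests on a number 4 percentage points higher from compound 1 to compound 3 (within the scatter) and on compound 2 at 91%. Expected, beside that earlier step, is a number 2 percentage points higher from compound 2 to compound 4 (within the scatter), a step of about the same size. Compound 4 is therefore estimated at 93%, with 82% to 102% as the likely range.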

Compound 4, a percentage reported as activity, at one concentration (the size of the read-out at that concentration, not a potency): 86%
Compound 4: the middle estimate sits 7 percentage points above what was measured; low and high end bracket the measured number.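

In this assay methoxy in place of hydrogen on an aromatic carbon made a number 5 percentage points lower from compound 2 to compound 4 (within the scatter) and so leaves the read-out within the scatter on this core too. Set beside the earlier step, the two cores cannot be told apart: the same change on two cores in this assay, a number 4 percentage points higher (within the scatter) from compound 1 to compound 3 and a number 5 percentage points lower (within the scatter) from compound 2 to compound 4, 9 percentage points apart, within the scatter of two such steps. This shows no difference in how the change carries from one core to the other, but it does not show that the change acts alike on both, nor that it has any effect on either.

Still open, from the compounds shown here alone, is whether a hydroxy group, a fluorine or an ethoxy chain at this place would move the read-out beyond the scatter. Also open, going by these compounds, is how the change behaves at any other concentration.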